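The source may hold more compounds than are shown below. What is called first, only, known or untested is meant among the compounds shown, and "the series" means these compounds.

Compound 1, `Cc1ccc(-c2cc(/N=C3/NC(=O)CS3)cs2)cc1`; in a functional assay on MCF7 cells (Homo sapiens) for cytotoxicity, read by MTT assay, with a stated time of 72 h (on this read-out higher numbers stand for weaker inhibition and lower numbers for stronger inhibition), compound 1 gives > 50000 nM, a limit of the assay.
Compound 2, `COc1ccc(-c2cc(/N=C3/NC(=O)CS3)cs2)cc1`; compound 2 gives > 50000 nM, also a limit.
Compound 3, `COc1cccc(N2C(=O)CS/C2=N\c2csc(-c3ccc(C)cc3)c2)c1`; compound 3 gives > 50000 nM, again a limit.

All three values sit at the limit of > 50000 nM in this assay, at which 3 of the 3 values shown sit, so the step that the two limits leave unreadable from compound 1 to compound 2 and the step that the two limits leave unreadable from compound 1 to compound 3 cannot be read. The change methoxy in place of methyl on an aromatic carbon recurs in compound 4, `COc1ccc(-c2cc(/N=C3\SCC(=O)N3c3cccc(OC)c3)cs2)cc1`, as methoxy in place of methyl on an aromatic carbon; the description of the second one also reads, cut one bond further out, 4-methylphenyl to 4-methoxyphenyl, so it is the same kind of change. The cores differ by 3-methoxyphenyl in place of hydrogen on an amide-type nitrogen in a ring.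

Compound 4 is expected to give 80000 nM, between 30000 nM and 300000 nM, most likely again only a limit, because compound 3 gives > 50000 nM and the same kind of change gave an unreadable a step that the two limits leave unreadable from compound 1 to compound 2. The expected step that the limit leaves unreadable from compound 3 to compound 4 is small.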

Compound 4, half-maximal inhibitory concentration: 1900 nM
The estimate for compound 4 lay 42-fold (1.62 log units) above the measured number, outside the stated range (below it).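

In this assay, methoxy in place of methyl on an aromatic carbon gives an at least 26-fold lower number from compound 3 to compound 4 (1.42 log units; beyond the scatter) on the core bearing 3-methoxyphenyl, whereas this change on the core of compound 1 cannot be read, nor can the step that adds 3-methoxyphenyl to compound 1: the limit of > 50000 nM in this assay, at which 3 of the 4 values shown sit.
On the methoxy-bearing core, 3-methoxyphenyl in place of hydrogen on an amide-type nitrogen in a ring gives an at least 26-fold lower number from compound 2 to compound 4 (1.42 log units; beyond the scatter), so each change is readable only where it completes compound 4. This does not show whether the methoxy change carries from one core to another, since one core gives a size and the other gives none.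

Left open is what an amine or a carboxylic acid in place of methoxy on the 4-methoxyphenyl group of compound 4 would give in this assay. Also open, on these data alone, is whether a longer chain can stand in place of 3-methoxyphenyl.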